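Fluoro-to-hydrogen step on the fused core of compound 1

The source may hold more compounds than are shown below. What is called first, only, known or untested is meant among the compounds shown, and "the series" means these compounds.

Compound 1 `O=S(=O)(c1ccc(F)cc1)c1cnc2cc(Cl)c(F)cc2c1-c1ccc(Cl)cc1` has no single number in an assay (strain Sprague-Dawley) for displacement of a labelled ligand from metabotropic glutamate receptor 5 (Rattus norvegicus), with a stated time of 60 min; on this read-out higher numbers stand for weaker inhibition and lower numbers for stronger inhibition: for compound 1 the entry reads "not determined" (no result reported). Compound 3 `O=S(=O)(c1ccc(F)cc1)c1cnc2ccc(Cl)cc2c1-c1ccc(Cl)cc1` is in the same position, with "not determined" (no result reported) for compound 3. The only measured anchor in the set is compound 2 `O=S(=O)(c1ccc(F)cc1)c1cnc2ccc(F)cc2c1-c1ccc(Cl)cc1`, which in this assay gives 180 nM. Compound 4 `O=S(=O)(c1ccc(F)cc1)c1cnc2cc(Cl)ccc2c1-c1ccc(Cl)cc1` differs from compound 1 by hydrogen in place of fluoro on an aromatic carbon. Among the compounds with values here, no step between two measured compounds is available, so the size of the step from compound 1 to compound 4 cannot be read from the data. Compound 2 and compound 4 share the sulfonyl and the chlorophenyl substituents and carry a single halogen on the fused carbon ring, so compound 4 is expected to land in the neighbourhood of what compound 2 shows, with any step from compound 1 anticipated to stay within the usual scatter rather than beyond it. On that basis compound 4 is estimated at 180 nM in this assay, with a range of 50 nM to 650 nM. The estimate rests on compound 2 alone and carries the width that a single anchor warrants.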

Compound 4, inhibition constant: 110 nM
Compound 4: the middle estimate sits 1.6-fold (0.21 log units) above what was measured; the measured number falls inside the stated range.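

No new step can be read: in this assay compound 1 has no single number, so the change from fluoro to hydrogen leading to compound 4 has no size. The compounds shown leave open what that fluoro contributes to inhibition in this assay. Nothing available here bears on the result for compound 4.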